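Benzylamine variation in a bis(trifluoromethyl)benzenesulfonamide series

A few compounds are considered here, and "the series" means these few. Any claim that something is new, unique, unknown or untested is made for them only; others in the source may bear on it.

Measured so far, all in a functional assay on PANC-1 cells (Homo sapiens) for inhibition, read by MTT assay, with a stated time of 72 h; a lower number here means a stronger inhibitor of growth, a higher number a weaker inhibitor of growth:
- compound 1, `CC(C)(C)c1ccc(CNCCCNS(=O)(=O)c2cc(C(F)(F)F)cc(C(F)(F)F)c2)cc1`, 2500 nM
- compound 2, `COc1ccc(CNCCCNS(=O)(=O)c2cc(C(F)(F)F)cc(C(F)(F)F)c2)cc1OC`, 18000 nM
- compound 3, `O=S(=O)(NCCCNCc1ccc(Cl)c(C(F)(F)F)c1)c1cc(C(F)(F)F)cc(C(F)(F)F)c1`, 10000 nM

The three compounds share the sulfonamide and the three-carbon chain to the secondary amine; they differ only in the aryl group on the saturated chain carbon bound to that amine nitrogen. Compound 3 gives the second highest number of the three in this assay. Its nearest neighbour is compound 2, which lies within the scatter of it, as the step of a 1.8-fold lower number from compound 2 to compound 3 (0.26 log units; within the scatter) shows. Against compound 1 it is clearly weaker: a 4.0-fold higher number from compound 1 to compound 3 (0.60 log units; beyond the scatter).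

Compound 4, `O=S(=O)(NCCCNCc1ccccc1)c1cc(C(F)(F)F)cc(C(F)(F)F)c1`, removes the ring substituents altogether: phenyl in place of 4-chloro-3-(trifluoromethyl)phenyl on a saturated chain carbon bound to an amine nitrogen. For the measured compounds named here, no measured step matches this change. Going by the values given here, the steps that bear on it both start from compound 1: a 7.2-fold higher number from compound 1 to compound 2 (0.86 log units; beyond the scatter) and a 4.0-fold higher number from compound 1 to compound 3 (0.60 log units; beyond the scatter). Both show that moving away from the tert-butyl group costs activity by a modest amount, and nothing here suggests an unsubstituted ring recovers it. Compound 4 is therefore expected to sit close to compound 3, perhaps slightly weaker, with the estimated step of a 1.5-fold higher number from compound 3 to compound 4 (0.18 log units; within the scatter) lying within the scatter. The estimate for compound 4 in this assay is 15000 nM, with a range from 5000 nM to 50000 nM.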

Compound 4, concentration for 50% growth inhibition: 16000 nM
Compound 4: the middle estimate sits 1.1-fold (0.03 log units) below what was measured, and the stated range covers the measured number.
By their numbers in this assay, from the lowest: compound 1; then compounds 3, 4 and 2 (each within the scatter of the next).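

In this assay, the unsubstituted ring gives this position a plain reference point: a 1.6-fold higher number from compound 3 to compound 4 (0.20 log units; within the scatter) and a 1.1-fold lower number from compound 2 to compound 4 (0.05 log units; within the scatter) both lie within the scatter, so neither the 4-chloro-3-(trifluoromethyl)phenyl group nor the 3,4-dimethoxyphenyl group can be told apart from phenyl. Only tert-butyl separates from that reference, with a 6.4-fold higher number from compound 1 to compound 4 (0.81 log units; beyond the scatter) beyond the scatter for hydrogen in place of tert-butyl on an aromatic carbon, so the series does not support a general gain from ring substitution, and compound 2 and compound 3 both go against such a reading. No supporting data accompany these results that could account for the difference between tert-butyl and the other groups.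

From the compounds shown here alone, it remains open whether the advantage of compound 1 is specific to tert-butyl or would also be seen with an isopropyl, cyclohexyl or trifluoromethoxy group in its place on the ring. Going by these compounds, the shared core also remains unexplored in these four compounds, including whether a longer chain or an amide in place of the secondary amine would keep the activity of compound 1 in this assay or lose it.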